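A few compounds are considered here, and "the series" means these few. Any claim that something is new, unique, unknown or untested is made for them only; others in the source may bear on it.

In a functional assay (Nicotiana tabacum) (on this read-out higher numbers stand for weaker inhibition and lower numbers for stronger inhibition), compound 1 `CCCNc1nc(SC)nc2ncccc12` gives 270 nM and compound 2 `C=CCNc1nc(SC)nc2ncccc12` gives 400 nM so the two numbers cannot be told apart. Compound 3 `CCOCCNc1nc(SC)nc2ncccc12` carries ethoxymethyl in place of vinyl on a saturated chain carbon bound to a nitrogen on an aromatic ring. For the measured compounds named here, the only measured step at this place is a 1.5-fold higher number from compound 1 to compound 2 (0.17 log units; within the scatter) and it exchanges ethyl for vinyl, so it offers a weak guide to ethoxymethyl. In this assay no step beyond the scatter is expected, and no direction can be drawn from the data (expected: a 1.1-fold higher number from compound 2 to compound 3 (0.05 log units; within the scatter)). For compound 3 the estimated value is 450 nM with an expected range of 150 nM to 1300 nM (an estimate only).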

Compound 3, half-maximal inhibitory concentration: 7590 nM
For compound 3 the middle estimate is 17-fold (1.23 log units) below the measured one, outside the stated range (above it).
By their numbers in this assay, from the lowest: compounds 1 and 2 (each within the scatter of the next); then compound 3.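

In this assay, this place is not indifferent to every exchange: the change from vinyl to ethoxymethyl on a saturated chain carbon bound to a nitrogen on an aromatic ring brings much weaker inhibition (a 19-fold higher number from compound 2 to compound 3 (1.28 log units; beyond the scatter)). Ethoxy in place of methyl on the chain shows a large loss as well (a 28-fold higher number from compound 1 to compound 3 (1.45 log units; beyond the scatter)), whereas the earlier exchange of ethyl for vinyl stayed within the scatter. No data on hand explain this loss.

The compounds shown do not separate the oxygen of the ethoxy group from the greater chain length. A longer all-carbon chain such as pentyl, set against a 2-hydroxyethyl group, would bear on that question.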